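The source may report more compounds than this note shows. Statements on the series, on what has been measured and on what is new or still open speak of the compounds shown alone.

Working notes on the series. In a functional assay on Jurkat cells (Homo sapiens) for cytotoxicity, read by MTT assay, with a stated time of 24 h (a higher number here means that more compound is needed for the effect, a lower number that less compound is needed), compound 1 (`CCOC(=O)c1cc([Se]Cc2ccccc2)c2cc(OC)ccc2n1`) gives 20800 nM and compound 2 (`CCOC(=O)c1cc(C#Cc2ccc(N)cc2)c2cc(OC)ccc2n1`) gives 61000 nM. Compound 2 thus stands at the higher of the two numbers, and its gap to compound 1 lies beyond the scatter. With only these two values, no pattern can be claimed for the series.

The next compound to be read is compound 3 (`CCOC(=O)c1cc(C#CCCO)c2cc(OC)ccc2n1`). It carries 2-hydroxyethyl in place of 4-aminophenyl on a triple-bonded carbon. For the measured compounds named here, no measured pair gives a step for a change of this kind, so the expectation has little to rest on. Going by the values given here, the only guides are the two values themselves, compound 1 at 20800 nM and compound 2 at 61000 nM, and both sit at high concentrations in this assay.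

The expected change, a 1.2-fold higher number from compound 2 to compound 3 (0.09 log units; within the scatter), is estimated to stay within the scatter, with a slight lean towards a higher number. A wide range is kept for that reason. For compound 3 the estimate is 75000 nM, with an expected range of 28000 nM to 200000 nM.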

Compound 3, half-maximal effective concentration: 123000 nM
Compound 3: the middle estimate sits 1.6-fold (0.21 log units) below what was measured, and the stated range covers the measured number.
By their numbers in this assay, from the lowest: compound 1; then compounds 2 and 3 (each within the scatter of the next).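

In this assay, 2-hydroxyethyl in place of 4-aminophenyl on a triple-bonded carbon gives a 2.0-fold higher number from compound 2 to compound 3 (0.30 log units; within the scatter), so a group with no ring and a group with a six-membered aromatic ring of carbon only are not told apart at this position, with the same count of hydrogen-bond donors and acceptors on both sides. For the compounds shown here, the group of 8 heavy atoms containing selenium on the aromatic carbon gives way to the group of 5 heavy atoms with a 5.9-fold higher number from compound 1 to compound 3 (0.77 log units; beyond the scatter), the only step here beyond the scatter; it is modest, and since the whole group changes, it does not separate the part played by selenium, the ring or the triple bond. Nothing at hand bears on why the numbers fall where they do.

Open, on these data alone, is whether a longer chain on the triple-bonded carbon, or an amine or a carboxylic acid in place of the hydroxyl at its end, would stand apart from compound 3 by more than the scatter. Also open, as far as these compounds go, is whether an unsubstituted phenyl would stand apart from compound 2, which would show whether the amino group on the ring counts at all.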